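Swapping chloro for methyl on a shared core

This account rests on a few compounds, and the source may have more. Where it says the series, first, only, none or still open, it means among the compounds named here.

Compound 1 `O=[N+]([O-])c1ccc(Nc2nc3c(N4CCCC4)ncnc3s2)cc1` gives 3630 nM in an assay on CHO cells for displacement of a labelled ligand from adenosine receptor A3 (Homo sapiens), read by scintillation counting, with a stated time of 3 h; a higher number here means a weaker inhibitor, a lower number a stronger inhibitor.
Compound 2 `Clc1ccc(Nc2nc3c(N4CCCC4)ncnc3s2)cc1` gives 4260 nM in this assay.
Compound 3 `Clc1ncnc2sc(Nc3cccc(Br)c3)nc12` gives 3900 nM in this assay.

Compound 2 stands among numbers that cannot be told apart: its value lies within the usual scatter of compound 3 and, slightly further off yet still within the scatter, of compound 1. Compound 4 `Cc1ccc(Nc2nc3c(N4CCCC4)ncnc3s2)cc1` differs from compound 2 by a single change: methyl in place of chloro on an aromatic carbon. Going by the values given here, only one measured step touches this same place on the ring, namely a 1.2-fold higher number from compound 1 to compound 2 (0.07 log units; within the scatter), and it shows that exchanging one small group for another there left the number essentially where it was. Among the compounds with values here, no measured compound carries a methyl group, so the expectation rests on that one step alone. On this basis, compound 4 is expected to show no step beyond the scatter relative to compound 2, that is a 1.1-fold lower number from compound 2 to compound 4 (0.03 log units; within the scatter). Compound 4 is therefore estimated at 4000 nM, with a range from 1500 nM to 11000 nM.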

Compound 4, inhibition constant: 563 nM
The estimate for compound 4 lay 7.1-fold (0.85 log units) above the measured number, and the stated range ends above it.
By their numbers in this assay, from the lowest: compound 4; then compounds 1, 3 and 2 (each within the scatter of the next).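

In this assay the group on this ring carbon clearly matters: methyl in place of chloro brings a 7.6-fold lower number from compound 2 to compound 4 (0.88 log units; beyond the scatter) and methyl in place of nitro brings a 6.4-fold lower number from compound 1 to compound 4 (0.81 log units; beyond the scatter) at the same place. Nitro and chloro had looked interchangeable here, with a 1.2-fold higher number from compound 1 to compound 2 (0.07 log units; within the scatter) as the only step then known at this place, so that flat step said little about what a third group would do. What sets methyl apart from the other two groups is not explained by any data at hand. The compounds shown leave open whether the lower number belongs to methyl alone or extends to ethyl or a longer chain. From the compounds shown here alone, whether an amine or a carboxylic acid on this ring carbon would keep the number low, or return it to the level of compound 1 and compound 2, also stays open.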